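Moving the Phenyl to the Other Methyl Position

The source may report more compounds than this note shows. Statements on the series, on what has been measured and on what is new or still open speak of the compounds shown alone.

Compound 1 `CCC(CC)C(=O)Cc1c(-c2ccc(Cl)cc2)nn2c(C)cc(C)nc12` gives 1.4 nM in an assay on cell membranes for displacement of a labelled ligand from Translocator protein (Rattus norvegicus), read by scintillation counting, with a stated time of 90 min; a higher number here means a weaker inhibitor, a lower number a stronger inhibitor.
Compound 2 `CCC(CC)C(=O)Cc1c(-c2ccc(Cl)cc2)nn2c(-c3ccccc3)cc(C)nc12` gives 2.5 nM in this assay.

Compound 1 carries the lowest number of the two measured compounds, but compound 2 sits so close that the two cannot be told apart: the change in this assay from compound 1 to compound 2 is a 1.8-fold higher number from compound 1 to compound 2 (0.25 log units; within the scatter), a phenyl in place of methyl on an aromatic carbon of the shared core.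

Compound 3 `CCC(CC)C(=O)Cc1c(-c2ccc(Cl)cc2)nn2c(C)cc(-c3ccccc3)nc12` has not yet been measured. It differs from compound 1 by phenyl in place of methyl on an aromatic carbon. Going by the values given here, this is the same kind of exchange as the one that led to compound 2, only at the other methyl-bearing aromatic carbon of the core. Among the compounds with values here, the only step that bears on it stayed within the scatter, so no movement beyond the scatter is expected in this assay for compound 3 either. The estimate for compound 3 is 2 nM, with a range from 0.7 nM to 6 nM. That estimate means a step of a 1.4-fold higher number from compound 1 to compound 3 (0.15 log units; within the scatter) from compound 1, which is expected to be small.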

Compound 3, inhibition constant: 2.7 nM
The estimate for compound 3 lay 1.4-fold (0.13 log units) below the measured number, within the range that was stated.
By their numbers in this assay, from the lowest: compounds 1, 2 and 3 (each within the scatter of the next).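

Putting phenyl in place of methyl on this aromatic carbon, next to the ring nitrogen, gives a 1.9-fold higher number from compound 1 to compound 3 (0.29 log units; within the scatter) in this assay. Read together with the exchange at the other methyl-bearing carbon, which gives a 1.8-fold higher number from compound 1 to compound 2 (0.25 log units; within the scatter), this shows that the same swap at either of the two places leaves the number within the scatter, so a single six-membered aromatic ring of carbon is accepted at both. Nothing measured here explains why these numbers stay so close.

The compounds shown leave open whether a group of a different kind, such as an amine or a carboxylic acid, would be accepted as well at this carbon. They also leave open what happens with phenyl on both carbons at once.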